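A few compounds are considered here, and "the series" means these few. Any claim that something is new, unique, unknown or untested is made for them only; others in the source may bear on it.

Working notes on the series in a functional assay on K562 cells (Homo sapiens), read by MTT assay, with a stated time of 3 days; a lower number here means a stronger inhibitor, a higher number a weaker inhibitor. Compound 1 (`CNc1ncnc2[nH]cc(Sc3cccs3)c12`) gives 4950 nM. Compound 2 (`c1coc(-c2ncnc3[nH]cc(Sc4cccs4)c23)c1`) gives 4260 nM, which lies within the scatter of compound 1, so the two are not separated on the numbers at hand. The next compound is compound 3 (`Cc1ncnc2[nH]cc(Sc3cccs3)c12`), with methyl in place of furan-2-yl on an aromatic carbon. Within the data shown here, one measured step bears on this change, since it concerns the same aromatic carbon: a 1.2-fold lower number from compound 1 to compound 2 (0.07 log units; within the scatter), with furan-2-yl in place of methylamino. Among the measured compounds shown here, that single step gives no sign of sensitivity to the group there, but no methyl compound has been measured yet, so the basis is thin. No change beyond the scatter is expected, and the expected step is a 1.2-fold higher number from compound 2 to compound 3 (0.07 log units; within the scatter). For compound 3 the estimated value is 5000 nM, with an expected range of 2300 nM to 11000 nM.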

Compound 3, half-maximal inhibitory concentration: 14000 nM
For compound 3 the middle estimate is 2.8-fold (0.45 log units) below the measured one, outside the stated range (above it).
By their numbers in this assay, from the lowest: compounds 2 and 1 (each within the scatter of the next); then compound 3.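

In this assay, this aromatic carbon proves not to be indifferent to its group: the step with methyl in place of furan-2-yl is a 3.3-fold higher number from compound 2 to compound 3 (0.52 log units; beyond the scatter), and the step with methyl in place of methylamino is a 2.8-fold higher number from compound 1 to compound 3 (0.45 log units; beyond the scatter). Both steps are modest but beyond the scatter, whereas furan-2-yl and methylamino remain within the scatter of each other, so among these three groups only methyl stands apart. No measurement at hand bears on the reason for this.

The compounds shown leave open whether an unsubstituted amine or a phenyl ring on this carbon would group with methyl or with furan-2-yl and methylamino. They also leave open whether the step holds when the rest of the shared core carries a different group.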